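The source may hold more compounds than are shown below. What is called first, only, known or untested is meant among the compounds shown, and "the series" means these compounds.

Measured so far in a functional assay for inhibition, with Homo sapiens as the target; on this read-out higher numbers stand for weaker inhibition and lower numbers for stronger inhibition:
Compound 1 `c1ccc(C(CC2CCCCC2)Nc2nc3ccccc3o2)cc1`: 340 nM; 8 nM; 6 nM (3 entries)
Compound 2 `Cc1ccc2oc(NC(CC3CCCCC3)C3=CN(C)NO3)nc2c1`: 26 nM

Compound 2 rests on a single number, 26 nM, and a further entry for it gives no single number. That number falls inside the wide spread seen for compound 1 (the several entries of compound 1 in this assay, 340 nM; 8 nM; 6 nM (3 entries)). Compound 3 `Cc1ccc2oc(NC(CC3CCCCC3)c3cccnc3)nc2c1` has yet to be measured in this assay. It differs from compound 2 as follows: a group of 6 heavy atoms (5 carbon, 1 nitrogen; one six-membered aromatic ring with 1 hetero atom) in place of a group of 6 heavy atoms (3 carbon, 2 nitrogen, 1 oxygen; one five-membered non-aromatic ring with 3 hetero atoms), on a saturated chain carbon bound to a nitrogen on an aromatic ring and a saturated chain carbon. The exchange sits on a saturated chain carbon bound to a nitrogen on an aromatic ring and a saturated chain carbon, and pyridin-3-yl is the incoming group. Among the measured compounds shown here, no measured step covers this exchange, so only a modest move towards weaker inhibition is expected, possibly none beyond the scatter. The estimated change is a 1.5-fold higher number from compound 2 to compound 3 (0.19 log units; within the scatter). For compound 3 the expected value is 40 nM, with an estimated range of 8 nM to 200 nM.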

Compound 3, half-maximal inhibitory concentration: 20 nM
For compound 3 the middle estimate is 2.0-fold (0.30 log units) above the measured one, and the stated range covers the measured number.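

Among the compounds shown here, at the saturated chain carbon bound to a nitrogen on an aromatic ring and a saturated chain carbon, this is the first exchange that can be read in this assay: a 1.3-fold lower number from compound 2 to compound 3 (0.11 log units; within the scatter). The two groups differ in ring size and aromaticity, and the count falls from 1 hydrogen-bond donor and 3 acceptors to 0 donors and 1 acceptor, yet the read-out does not move beyond the scatter. This reading rests on single numbers, and repeat entries in this assay can lie far apart, as seen in: the several entries of compound 1 in this assay, 340 nM; 8 nM; 6 nM (3 entries)

The compounds shown leave open whether a carboxylic acid or an open-chain amine at this place would keep the number in the same range. For the compounds shown here, they also leave open what the ring nitrogen of pyridin-3-yl contributes, as no pair among them differs in that one feature alone.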